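The source may report more compounds than this note shows. Statements on the series, on what has been measured and on what is new or still open speak of the compounds shown alone.

Compound 1, `CNS(=O)(=O)Cc1noc2ccccc12`, gives 23 mg/kg in a functional assay on the whole organism (strain STD-dd) with Mus musculus as the target, in the maximal electroshock model, with a stated time of 2 h; a lower number here means that less compound is needed, a higher number that more compound is needed for the effect. Compound 2, `CCNS(=O)(=O)Cc1noc2ccccc12`, gives 39 mg/kg. Compound 3, `CNS(=O)(=O)Cc1noc2ccc(F)cc12`, gives 35 mg/kg.

Compound 3 stands second highest of the three numbers, yet its gaps to compound 1 and to compound 2 are both within the scatter, so no order among the three can be read. The step to compound 4, `CN(C)S(=O)(=O)Cc1noc2ccc(F)cc12`, is methyl in place of hydrogen on a sulfonamide nitrogen. For the measured compounds named here, the one measured step that bears on it is a 1.7-fold higher number from compound 1 to compound 2 (0.23 log units; within the scatter), which also built out the substituent around the sulfonamide nitrogen and stayed within the scatter. A step of similar size, toward a higher number or none beyond the scatter, is therefore expected in this assay. Compound 4 is accordingly estimated at 50 mg/kg, between 25 mg/kg and 100 mg/kg, an expected step of a 1.4-fold higher number from compound 3 to compound 4 (0.15 log units; within the scatter).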

Compound 4, dose for half-maximal effect: 32 mg/kg
Estimate against measurement, compound 4: 1.6-fold (0.19 log units) above; the measured number falls inside the stated range.
By their numbers in this assay, from the lowest: compounds 1, 4, 3 and 2 (each within the scatter of the next).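

In this assay, the step to a second methyl on the sulfonamide nitrogen is a 1.1-fold lower number from compound 3 to compound 4 (0.04 log units; within the scatter) and stays within the scatter. For the compounds shown here, compound 4 thus shows that this nitrogen can lose its remaining hydrogen, as the dimethylamino group, without a change that can be read, whereas the earlier compounds only showed methyl and ethyl with that hydrogen in place. Nothing available gives a reason for this result. On these data alone, whether a longer chain such as butyl, or a benzyl group, on this nitrogen would move the number beyond the scatter stays open. So does the effect of a free amino group at this place.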